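Shortening the acyl chain of an amide-linked trimethoxyphenyl inhibitor

The source may hold more compounds than are shown below. What is called first, only, known or untested is meant among the compounds shown, and "the series" means these compounds.

Measured so far:
compound 1, `C/C=C/C(=O)N(Cc1cccc(O)c1)c1cc(OC)c(OC)c(OC)c1`, 6700 nM
compound 2, `CCC/C=C/C(=O)N(Cc1ccc(OC)c(O)c1)c1cc(OC)c(OC)c(OC)c1`, 95 nM

In a functional assay on HCT-116 cells (Homo sapiens) for inhibition, read by MTT assay, with a stated time of 48 h (a higher number here means a weaker inhibitor, a lower number a stronger inhibitor), compound 2 gives the lowest of the two numbers; compound 1 sits far higher, beyond the scatter. Compound 3, `CCC(=O)N(Cc1ccc(OC)c(O)c1)c1cc(OC)c(OC)c(OC)c1`, has not yet been measured. It differs from compound 2 in one place: ethyl in place of pent-1-en-1-yl on a carbonyl carbon. Among the measured compounds shown here, no measured pair shows this exact change, so its size is uncertain. Compound 1 hints that a shorter unsaturated chain on the carbonyl carbon goes with a weaker inhibitor, although compound 1 also differs in its phenol ring. The step from compound 2 to compound 3 is expected to be a 16-fold higher number from compound 2 to compound 3 (1.20 log units; beyond the scatter), toward a weaker inhibitor. Compound 3 is therefore estimated at 1500 nM, within 300 nM to 8000 nM.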

Compound 3, half-maximal inhibitory concentration: 61 nM
Beside the measured number, compound 3's estimate is 25-fold (1.39 log units) above it; the whole stated range lies above it.
By their numbers in this assay, from the lowest: compounds 3 and 2 (each within the scatter of the next); then compound 1.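

On the carbonyl carbon, ethyl in place of pent-1-en-1-yl gives a 1.6-fold lower number from compound 2 to compound 3 (0.19 log units; within the scatter) in this assay. Unlike the comparison with compound 1, this pair changes only the chain, so the shorter chain's effect can be read directly: at this position, neither the double bond nor the longer chain is needed to keep the reading at this level. Nothing measured here explains this result.

From the compounds shown here alone, how methyl, a longer saturated chain such as pentyl, or an amine on that carbonyl carbon would read remains open.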